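Amide variation on a shared dimethoxy core: morpholine amide

The source may report more compounds than this note shows. Statements on the series, on what has been measured and on what is new or still open speak of the compounds shown alone.

Measured compounds:
- compound 1, `COc1cc2c(cc1OC)C(CC(=O)N(C)C)CC2`, 34.8%
- compound 2, `CCCCNC(=O)CC1CCc2cc(OC)c(OC)cc21`, 27.5%
- compound 3, `COc1cc2c(cc1OC)C(CC(=O)N1CCNCC1)CC2`, 42%

All three share one core and differ only in the group on the carbonyl carbon. In a functional assay on the whole organism (strain Wistar) for inhibition, with Rattus norvegicus as the target, read by paw edema, with stated times of 60 min and 3 h, at a dose of 100 mg/kg by the oral route (a lower number here means less inhibition, a higher number more inhibition at the dose given (going by the name of the read-out)), compound 1 gives 34.8%. Its values to both neighbours lie within the scatter: a number 7.3 percentage points lower from compound 1 to compound 2 (within the scatter) and a number 7.2 percentage points higher from compound 1 to compound 3 (within the scatter). Going by the values given here, only the step of a number 14.5 percentage points higher from compound 2 to compound 3 (beyond the scatter) reaches beyond the scatter, and it is modest.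

Compound 4, `COc1cc2c(cc1OC)C(CC(=O)N1CCOCC1)CC2`, is not yet measured. Compared with compound 1 the change is morpholin-4-yl in place of dimethylamino on a carbonyl carbon. Among the compounds with values here, the most relevant measured step is the one from compound 1 to compound 3, where a different six-membered ring amine entered on the same carbonyl carbon and the number moved only within the scatter. On that basis a similar outcome is expected: a step of a number 3.2 percentage points higher from compound 1 to compound 4 (within the scatter), small and not clearly beyond the scatter, in either direction. The estimate for compound 4 is 38%, with a range from 25% to 50%.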

Compound 4, a percentage reported as inhibition, in the whole organism at one dose (the size of the read-out at that dose, not a potency): 19.6%
Compound 4: middle estimate off by 18.4 percentage points, on the high side; measured number outside the range, below it.
By their numbers in this assay, from the lowest: compounds 4, 2, 1 and 3 (each within the scatter of the next, the first and the last beyond it).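

In this assay, ring amines on the carbonyl carbon do not behave alike: morpholin-4-yl in place of piperazin-1-yl gives a number 22.4 percentage points lower from compound 3 to compound 4 (beyond the scatter), although the morpholin-4-yl ring differs by holding an oxygen where the piperazin-1-yl ring holds a nitrogen. A ring at this place therefore does not set the number by itself, as morpholin-4-yl in place of dimethylamino gives a number 15.2 percentage points lower from compound 1 to compound 4 (beyond the scatter), so what the ring contains matters here. The open-chain butylamino amide does not separate from the morpholine amide, with a number 7.9 percentage points lower from compound 2 to compound 4 (within the scatter).

Nothing measured here explains why these two rings part ways.

Also open, going by these compounds, is whether the ring nitrogen raises the number or the ring oxygen lowers it, a question that a piperidin-1-yl amide, with a ring carbon at that spot, could help settle.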